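A few compounds are considered here, and "the series" means these few. Any claim that something is new, unique, unknown or untested is made for them only; others in the source may bear on it.

Measured in an ADME assay on microsomes from liver (Canis lupus familiaris) for metabolic stability; on this read-out lower numbers stand for a shorter-lived compound and higher numbers for a longer-lived compound (every value here is a limit of the assay, not a number):

compound 1 `Nc1nc(NCCNc2ncc(-c3ncc[nH]3)c(-c3cc(F)c(F)cc3F)n2)ccc1[N+](=O)[O-]` gives > 0.5 h
compound 2 `Nc1nc(NCCNc2ncc(-c3ncc[nH]3)c(-c3cc(F)ccc3Cl)n2)ccc1[N+](=O)[O-]` gives > 0.5 h
compound 3 `Nc1nc(NCCNc2ncc(-c3ncc[nH]3)c(-c3ccc(Br)cc3Cl)n2)ccc1[N+](=O)[O-]` gives > 0.5 h

Compound 3 stands at a limit (> 0.5 h) and has no number of its own. All the measured compounds sit at this same limit (the limit of > 0.5 h in this assay, at which 3 of the 3 values shown sit).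

The step to compound 4 `Cc1ccc(-c2nc(NCCNc3ccc([N+](=O)[O-])c(N)n3)ncc2-c2ncc[nH]2)c(Br)c1` puts 2-bromo-4-methylphenyl in place of 4-bromo-2-chlorophenyl on an aromatic carbon. The change falls at the same place as the three measured exchanges of this phenyl group: a step that the two limits leave unreadable from compound 1 to compound 2; a step that the two limits leave unreadable from compound 1 to compound 3; a step that the two limits leave unreadable from compound 2 to compound 3. None of these steps has a readable size, so they give no measure of how far such an exchange moves the half-life.

The expectation in this assay therefore rests on the limit of compound 3 (> 0.5 h) and is for no step beyond the scatter, in either direction. The estimated step (a step that the limit leaves unreadable from compound 3 to compound 4) is expected to stay within the scatter. A result reported again only as a limit is also expected to be the likely outcome. The expected value for compound 4 is 0.8 h with an estimated range from 0.45 h to 1.6 h as its span.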

Compound 4, half-life: > 0.5 h
Compound 4 gave a limit, no number (the forecaster's own chance of this, stated with the estimate: 80%); the middle value does not contradict the limit.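

Compound 4 also returns only a limit, so none of its steps from compound 1, compound 2 and compound 3 in this assay can be read: the limit of > 0.5 h in this assay, at which 4 of the 4 values shown sit. The compounds shown leave open how far any of these phenyl exchanges moves the half-life, and whether the half-lives of the four compounds differ at all.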